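The source may report more compounds than this note shows. Statements on the series, on what has been measured and on what is new or still open speak of the compounds shown alone.

Compound 1 `CSc1ccc(/C=C(\C(=O)c2ccc(Br)cc2)S(=O)(=O)Cc2ccc(F)cc2)cc1` and compound 2 `CSc1ccc(/C=C(\C(=O)c2ccc(Br)cc2)S(=O)(=O)c2ccc(C)cc2)cc1` share a core and differ in one group on a sulfonyl sulfur. In a functional assay on DU-145 cells (Homo sapiens) for inhibition, read by trypan blue exclusion, with a stated time of 96 h (on this read-out higher numbers stand for weaker inhibition of growth and lower numbers for stronger inhibition of growth), compound 1 gives 50000 nM, and compound 2 gives 1000 nM. The change between them is 4-methylphenyl in place of 4-fluorobenzyl on a sulfonyl sulfur, and it made the step of a 50-fold lower number from compound 1 to compound 2 (1.70 log units; beyond the scatter).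

Compound 3 `COc1cc(OC)c(/C=C(\C(=O)c2ccc(Cl)cc2)S(=O)(=O)Cc2ccc(F)cc2)c(OC)c1` carries a different core; the difference between its core and the core of compound 1 is not broken down here. In this assay compound 3 gives 25000 nM, a number that is within the usual scatter of the number for compound 1.

Compound 4 `COc1cc(OC)c(/C=C(\C(=O)c2ccc(Cl)cc2)S(=O)(=O)c2ccc(C)cc2)c(OC)c1` is related to compound 3 in the same way that compound 2 is related to compound 1: the change is 4-methylphenyl in place of 4-fluorobenzyl on a sulfonyl sulfur, the same change, at the same kind of place on the sulfonyl sulfur. Within the data shown here, whether a move of the same kind on a different core repeats its effect cannot be taken for granted, since only one measured pair shows it. Among the measured compounds shown here, still, the one example is large and far beyond the scatter, so it is the best guide available.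

On this basis the step from compound 3 to compound 4 in this assay is expected to be about a 50-fold lower number from compound 3 to compound 4 (1.70 log units; beyond the scatter), resting on the size of a 50-fold lower number from compound 1 to compound 2 (1.70 log units; beyond the scatter). Compound 4 is therefore estimated at 500 nM, with a plausible range from 150 nM to 2500 nM.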

Compound 4, concentration for 50% growth inhibition: 25000 nM
For compound 4 the middle estimate is 50-fold (1.70 log units) below the measured one, and the stated range ends below it.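

In this assay, putting 4-methylphenyl in place of 4-fluorobenzyl on the sulfonyl sulfur gives no change at the digits printed from compound 3 to compound 4 (within the scatter), so the large improvement in growth inhibition seen on the core of compound 1 does not appear on the core of compound 3. The effect of this change therefore depends on the core that carries it, and its size on one core is no safe guide to its size on another: the same change on two cores in this assay, a 50-fold lower number (1.70 log units; beyond the scatter) from compound 1 to compound 2 and no change at the digits printed (within the scatter) from compound 3 to compound 4, 50-fold (1.70 log units) apart, beyond the scatter of two such steps This does not show which feature of the core is responsible, as the core of compound 1 and the core of compound 3 differ in more than one place, and two pairs cannot set a general rule for the series.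

The compounds shown leave open whether the methylthio group, the methoxy groups or the choice of bromine or chlorine decides if the change pays off, which a compound differing from compound 1 in only one of these would help to settle. They also leave open whether the gain on the core of compound 1 follows from the loss of the fluorine, the added methyl or the removed chain carbon, which 4-fluorophenyl or 4-methylbenzyl on the sulfonyl sulfur could separate.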